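The source may report more compounds than this note shows. Statements on the series, on what has been measured and on what is new or still open speak of the compounds shown alone.

Measured so far in a functional assay on HepG2 cells (Homo sapiens) for inhibition, read by MTT assay, with a stated time of 24 h; on this read-out higher numbers stand for weaker inhibition and lower numbers for stronger inhibition:
- compound 1 `CC1(C)[C@H]2CC[C@]1(C)N(Cc1cn(-c3cccc(Cl)c3)nn1)C(=O)C2` gives 60 nM
- compound 2 `CC1(C)[C@H]2CC[C@]1(C)N(Cc1cn(-c3ccccc3C#N)nn1)C(=O)C2` gives 180 nM
- compound 3 `CC1(C)[C@H]2CC[C@]1(C)N(Cc1cn(-c3ccc(F)cc3)nn1)C(=O)C2` gives 90 nM

Compound 3 sits within the scatter of both others on this read-out: a 1.5-fold higher number from compound 1 to compound 3 (0.18 log units; within the scatter), and a 2.0-fold lower number from compound 2 to compound 3 (0.30 log units; within the scatter). Among the compounds with values here, the only step that clears the scatter is a 3.0-fold higher number from compound 1 to compound 2 (0.48 log units; beyond the scatter), so the aryl group on the triazole nitrogen has so far moved the number only modestly at most.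

Compound 4 `CC1(C)[C@H]2CC[C@]1(C)N(Cc1cn(-c3cccc(O)c3)nn1)C(=O)C2` is the next point. The change from compound 3 is 3-hydroxyphenyl in place of 4-fluorophenyl on an aromatic nitrogen.

Within the data shown here, the steps that bear on this are the three aryl swaps already in hand: two of them fall within the scatter and the third is modest. Among the measured compounds shown here, none of them involved a hydrogen-bond donor or acceptor on the phenyl, so the hydroxyl is a new feature with no direct precedent here. Given that the measured aryl swaps moved the number little, the expectation for this assay is a step of a 1.1-fold higher number from compound 3 to compound 4 (0.05 log units; within the scatter), most likely none beyond the scatter, with the range widened to allow for the untested donor and acceptor.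

Compound 4 is therefore expected to give about 100 nM in this assay, estimated to lie between 40 nM and 280 nM.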

Compound 4, half-maximal inhibitory concentration: 70 nM
For compound 4 the middle estimate is 1.4-fold (0.15 log units) above the measured one, within the range that was stated.
By their numbers in this assay, from the lowest: compounds 1, 4, 3 and 2 (each within the scatter of the next, the first and the last beyond it).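

In this assay, compound 4 brings a hydrogen-bond donor and a hydrogen-bond acceptor onto the phenyl at this aromatic nitrogen, yet neither closest comparison clears the scatter: a 1.3-fold lower number from compound 3 to compound 4 (0.11 log units; within the scatter) against 4-fluorophenyl, and a 1.2-fold higher number from compound 1 to compound 4 (0.07 log units; within the scatter) where hydroxy replaces chloro on an aromatic carbon. Within the data shown here, the only step here beyond the scatter is a modest one, a 2.6-fold lower number from compound 2 to compound 4 (0.41 log units; beyond the scatter), which joins the earlier step from compound 1 in setting 2-cyanophenyl apart, although compound 3 remains within the scatter of compound 2. Nothing measured here gives a reason for the size of any of these steps.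

On these data alone, it remains open whether the hydroxy itself matters, which a methoxy or an amine in its place could test, while a carboxylic acid on the phenyl would show whether a charged group is accepted at this position. Also open, as far as these compounds go, is whether an aromatic ring is needed on this nitrogen at all, a question that a cyclohexyl or a benzyl group in place of the phenyl could address.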